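Chloro in Place of Fluoro: What Compound 3 Should Show

The source may hold more compounds than are shown below. What is called first, only, known or untested is meant among the compounds shown, and "the series" means these compounds.

Measured compounds:
compound 1, `Cc1c(OC[C@H](C)COc2ccc(F)c(C(=O)O)c2)ccc(C(=O)CC(C)(C)C)c1O`: 294 nM
compound 2, `Cc1c(OC[C@@H](C)COc2ccc(F)c(C(=O)O)c2)ccc(C(=O)CC(C)(C)C)c1O`: 112 nM

Of the compounds shown here, two have been measured so far in an assay for positive allosteric modulation of metabotropic glutamate receptor 2 (Rattus norvegicus); on this read-out higher numbers stand for an effect only at larger amounts of compound and lower numbers for an effect already at smaller amounts. Compound 1 gives 294 nM, and compound 2 gives 112 nM, the lowest of the two numbers. Within the data shown here, the only measured step is a 2.6-fold lower number from compound 1 to compound 2 (0.42 log units; beyond the scatter), and it rests solely on (the fact that compounds 1 and 2 differ only in the configuration as drawn).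

Compound 3, `Cc1c(OC[C@@H](C)COc2ccc(Cl)c(C(=O)O)c2)ccc(C(=O)CC(C)(C)C)c1O`, is not yet measured. It differs from compound 2 by chloro in place of fluoro on an aromatic carbon. Among the measured compounds shown here, no measured step bears on this change: the single step in hand, a 2.6-fold lower number from compound 1 to compound 2 (0.42 log units; beyond the scatter), concerns configuration alone and says nothing about a halogen exchange on the aromatic ring. With no guidance from the data, the expectation for compound 3 is a step of no more than the usual scatter in this assay, in either direction, so that the number stays close to that of compound 2; this expected step is a 1.1-fold lower number from compound 2 to compound 3 (0.05 log units; within the scatter). The estimate for compound 3 in this assay is therefore 100 nM, with a range from 40 nM to 300 nM.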

Compound 3, half-maximal effective concentration: 377 nM
The estimate for compound 3 lay 3.8-fold (0.58 log units) below the measured number; the measured number lies above the stated range.
By their numbers in this assay, from the lowest: compound 2; then compounds 1 and 3 (each within the scatter of the next).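

In this assay, the halogen on this ring carbon turns out to matter: chloro in place of fluoro gives a 3.4-fold higher number from compound 2 to compound 3 (0.53 log units; beyond the scatter). The change from 3-carboxy-4-fluorophenyl to 3-carboxy-4-chlorophenyl thus shows that this position, ortho to a carboxy group and para to a large group, is not indifferent to which halogen it carries, with fluoro in compound 2 giving the lower number of this pair, something the earlier pair, which differed only in configuration, could not reveal. Nothing available bears on what lies behind this halogen step.

The compounds shown leave open how hydrogen, methyl, bromo or a nitrile on this same carbon would read, and so whether the step reflects something favourable about fluoro, something unfavourable about chloro, or a broader trend across such groups. They also leave open whether the same exchange would give a step of similar size and direction in the configuration drawn in compound 1, or whether the halogen and the stereocentre act independently of each other.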